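Swapping the benzyl substituent of compound 1 for 4-chlorobenzyl

The compounds below may be only part of what the source reports. "The series", "measured", "known", "first", "only" and "open" are said of these compounds alone.

Three amides built on the shared core have been tested in a functional assay on HCT-116 cells (Homo sapiens) for antiproliferative activity, read by MTT assay, with a stated time of 48 h; on this read-out lower numbers stand for stronger inhibition and higher numbers for weaker inhibition. Compound 1 `COc1ccc(CN(C(=O)CSc2nc3ccccc3s2)c2cc(OC)c(OC)c(OC)c2)cc1C` gives 17100 nM, the second highest of the three numbers. Compound 2 `COc1cc(N(Cc2ccc(Br)cc2)C(=O)CSc2nc3ccccc3s2)cc(OC)c1OC` gives 63800 nM, and compound 3 `COc1ccc(CN(C(=O)CSc2nc3ccccc3s2)c2cc(OC)c(OC)c(OC)c2)cc1N=[N+]=[N-]` gives 2860 nM. The step of a 3.7-fold higher number from compound 1 to compound 2 (0.57 log units; beyond the scatter) is beyond the scatter, as is the step of a 6.0-fold lower number from compound 1 to compound 3 (0.78 log units; beyond the scatter), and the two ends are separated by a 22-fold lower number from compound 2 to compound 3 (1.35 log units; beyond the scatter).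

Compound 4 `COc1cc(N(Cc2ccc(Cl)cc2)C(=O)CSc2nc3ccccc3s2)cc(OC)c1OC` has not yet been measured in this assay. It differs from compound 1 as follows: 4-chlorophenyl in place of 4-methoxy-3-methylphenyl on a saturated chain carbon bound to an amide-type nitrogen. Within the data shown here, the nearest guide is compound 2, where the move to a halogen-bearing benzyl produced a 3.7-fold higher number from compound 1 to compound 2 (0.57 log units; beyond the scatter); compound 4 carries a halogen at the same place, so a similar weakening is expected, with no measured step pointing the other way. Compound 4 is therefore estimated to give 50000 nM, within 20000 nM to 120000 nM. That estimate corresponds to an expected step of a 2.9-fold higher number from compound 1 to compound 4 (0.47 log units; beyond the scatter).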

Compound 4, half-maximal inhibitory concentration: 603000 nM
Compound 4: middle estimate off by 12-fold (1.08 log units), on the low side; measured number above the stated range.
By their numbers in this assay, from the lowest: compound 3; then compound 1; then compound 2; then compound 4.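

In this assay the position on the saturated chain carbon bound to an amide-type nitrogen proves sensitive to the identity of the halogen, since chloro in place of bromo on an aromatic carbon alone gives a clear weakening (a 9.5-fold higher number from compound 2 to compound 4 (0.98 log units; beyond the scatter)). Halogen-bearing benzyl groups therefore do not form one uniform class here, and 4-chlorophenyl in place of 4-methoxy-3-methylphenyl costs far more (a 35-fold higher number from compound 1 to compound 4 (1.55 log units; beyond the scatter)) than the earlier move to the bromo compound did. The same position now spans a much wider range than before, with 4-chlorophenyl in place of 3-azido-4-methoxyphenyl giving the largest step in the series (a 210-fold higher number from compound 3 to compound 4 (2.32 log units; beyond the scatter)).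

No available evidence explains the gap between the chloro and bromo compounds. Going by these compounds, whether fluoro at the same place would read closer to compound 2 or to compound 4, and how an unsubstituted benzyl would compare, remains open.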